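The compounds below may be only part of what the source reports. "The series", "measured", "known", "first", "only" and "open" are said of these compounds alone.

Compound 1 `CCc1cc(-c2ccc(F)cc2)c(O)cc1OCCCOc1cccc(OC)c1CCC(=O)O` and compound 2 `CCCc1c(OCCCOc2cc(O)c(-c3ccc(F)cc3)cc2CC)ccc2c1OC(C(=O)O)CC2` have both been tested in an assay on membranes from lung (Cavia porcellus) for binding affinity to leukotriene B4 receptor (Homo sapiens), read by radioligand binding; on this read-out lower numbers stand for stronger inhibition and higher numbers for weaker inhibition. In this assay compound 1 gives 6.4 nM, and compound 2 gives 4.4 nM. On the numbers shown, compound 1 has the higher value of the two, though its gap to compound 2 lies within the scatter, so the pair cannot be told apart. Compound 3 `CCc1cc(-c2ccc(F)cc2)c(O)cc1OCCCOc1cccc(CCCCC(=O)O)c1CCC(=O)O` has not been measured. It differs from compound 1 in one place: 4-carboxybutyl in place of methoxy on an aromatic carbon. The group that enters brings an additional carboxylic acid into the molecule. Within the data shown here, no measured pair shows the effect of such a change, so the expectation rests only on the value of compound 1. The step from compound 1 to compound 3 is expected to be a 1.3-fold lower number from compound 1 to compound 3 (0.11 log units; within the scatter), meaning no shift beyond the scatter in either direction. Compound 3 is accordingly estimated at 5 nM, with a range from 1.5 nM to 20 nM.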

Compound 3, inhibition constant: 0.71 nM
For compound 3 the middle estimate is 7.0-fold (0.85 log units) above the measured one; the measured number lies below the stated range.
By their numbers in this assay, from the lowest: compound 3; then compounds 2 and 1 (each within the scatter of the next).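

Replacing methoxy with 4-carboxybutyl on this aromatic carbon, ortho to the 2-carboxyethyl group, gives a 9.0-fold lower number from compound 1 to compound 3 (0.95 log units; beyond the scatter) in this assay and so shows that the position is not a silent one. It also shows that the position tolerates a much larger group, 7 heavy atoms in place of 2, and that a molecule with an additional carboxylic acid can bind more tightly here. No evidence is available to explain this gain.

Among these compounds, the single step joins a longer chain and a new carboxylic acid, so it cannot show which of the two goes with the lower number. A plain butyl chain, which has no acid, and a shorter carboxymethyl group, which keeps the acid, would be the comparisons that pull these two features apart.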